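The compounds below may be only part of what the source reports. "The series", "measured", "known", "first", "only" and "open" are said of these compounds alone.

Measured so far in a functional assay for antagonist activity at transient receptor potential cation channel subfamily V member 1 (Rattus norvegicus); on this read-out lower numbers stand for stronger inhibition and higher numbers for weaker inhibition:

- compound 1, `Cc1cccnc1-c1ccc(C(=O)Nc2ccc(F)cc2)cc1`, in this assay compound 1 reads > 4000 nM; this is a limit of the assay, not a number (the limit of > 4000 nM in this assay, at which 1 of the 3 values shown sits).
- compound 2, `Cc1cccnc1-c1ccc(C(=O)Nc2ccc(Cl)cc2)cc1`, in this assay compound 2 gives 2020 nM.
- compound 3, `CCS(=O)(=O)Nc1cccnc1-c1ccc(C(=O)Nc2ccc(C(C)(C)C)cc2)cc1`, in this assay compound 3 gives 4 nM.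

Compound 3 holds the lowest of the two numbers shown; its nearest neighbour is compound 2, which sits far higher, well beyond the scatter. Among the compounds with values here, the single measured step, an at least 1.9-fold lower number from compound 1 to compound 2 (0.29 log units; that floor lies within the scatter), is a halogen exchange on the anilide ring and does not touch the position now in question, so it gives no guide for the change under review.

Compound 4, `Cc1nnc(-c2cccnc2-c2ccc(C(=O)Nc3ccc(C(C)(C)C)cc3)cc2)o1`, differs from compound 3 in one place: 5-methyl-1,3,4-oxadiazol-2-yl in place of (ethylsulfonyl)amino on an aromatic carbon. The group that leaves carries the only hydrogen-bond donor on that ring in compound 3; the group that enters is a small aromatic heterocycle of the same heavy-atom count. Within the data shown here, no measured pair in this set exchanges a substituent at this position, so the size and direction of the step are open; the expectation is worded as a modest rise in the number, with a wide band to cover either outcome.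

For compound 4 the estimated value in this assay is 20 nM, with a range from 3 nM to 200 nM, which means an expected step of a 5.0-fold higher number from compound 3 to compound 4 (0.70 log units; beyond the scatter).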

Compound 4, half-maximal inhibitory concentration: 34 nM
Compound 4: the middle estimate sits 1.7-fold (0.23 log units) below what was measured; the range from low to high includes it.
By their numbers in this assay, from the lowest: compound 3; then compound 4; then compound 2. At a limit, above all of these: compound 1.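

In this assay, within the data shown here, the first measured exchange at this position, ortho to a large group, gives an 8.5-fold higher number from compound 3 to compound 4 (0.93 log units; beyond the scatter) and so shows that the position responds to the choice of substituent. The (ethylsulfonyl)amino group is not essential for inhibition in this series: compound 4, whose 5-methyl-1,3,4-oxadiazol-2-yl group has 0 hydrogen-bond donors, still gives 34 nM in this assay even though the step is beyond the scatter. The exchange alters the ring count, the donor count and the acceptor count together, and nothing measured here separates these changes or gives a cause for the step.

Compounds 1 and 2 differ from compounds 3 and 4 in more than one place, so their values cannot be used to judge the substituent at this position on its own. Going by these compounds, how a primary amine, a carboxylic acid or a longer chain on the sulfonyl group would read at this position stays open, as does the contribution of the methyl on the oxadiazole.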